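The source may hold more compounds than are shown below. What is called first, only, known or untested is meant among the compounds shown, and "the series" means these compounds.

Compound 2 `O=C(c1ccc(Cl)cc1)c1ccc2c(c1)oc(=O)n2C(=O)NCCCCc1ccccc1` and compound 1 `O=C(NCCCCc1ccccc1)n1c(=O)oc2ccc(Br)cc21` were both tested in an assay on HEK293 cells for inhibition of acid ceramidase (Homo sapiens), with a stated time of 10 min; a lower number here means a stronger inhibitor, a higher number a weaker inhibitor. Compound 2 gives 14 nM, and compound 1 gives 22 nM. Compound 2 thus shows the lower of the two numbers, but its gap to compound 1 lies within the scatter, so neither is set apart. Compound 3 `O=C(NCCCCc1ccccc1)n1c(=O)oc2cc([N+](=O)[O-])ccc21` has not yet been measured in this assay; it differs from compound 2 in one place: nitro in place of (4-chlorophenyl)carbonyl on an aromatic carbon. Because compound 1 reaches 22 nM with only a small group at the core, the step of a 2.1-fold higher number from compound 2 to compound 3 (0.33 log units; beyond the scatter) is expected to be modest, toward a slightly higher number or none beyond the scatter. Compound 3 is therefore estimated at 30 nM, within 10 nM to 90 nM.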

Compound 3, half-maximal inhibitory concentration: 3 nM
Compound 3: the middle estimate sits 10-fold (1.00 log units) above what was measured; the measured number lies below the stated range.
By their numbers in this assay, from the lowest: compound 3; then compounds 2 and 1 (each within the scatter of the next).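

In this assay, the swap at this aromatic carbon gives a 4.7-fold lower number from compound 2 to compound 3 (0.67 log units; beyond the scatter), a step beyond the scatter. The position therefore does not need the (4-chlorophenyl)carbonyl group and its aromatic ring to reach a low number, as the ringless nitro serves better here. Nothing available explains this step. The compounds shown leave open whether an amine, a carboxylic acid or a nitrile at this same carbon would keep the low number. They also leave open how a plain hydrogen there would compare with nitro.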